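The source may hold more compounds than are shown below. What is called first, only, known or untested is meant among the compounds shown, and "the series" means these compounds.

Working notes on the series. Within the data shown here, in a physicochemical assay for lipophilicity, measured as octanol-water partition (on this read-out lower numbers stand for lower lipophilicity and higher numbers for higher lipophilicity), compound 1 `O=C(NNc1ccnc2cc(Cl)ccc12)c1ccccc1/N=C/c1ccc(Cl)c(Cl)c1` gives 6.22 on the scale, and compound 2 `CN(C)c1ccc(/C=N/c2ccccc2C(=O)NNc2ccnc3cc(Cl)ccc23)cc1` gives 5.03 as the lower of the two numbers so far. Compound 3 `O=C(NNc1ccnc2cc(Cl)ccc12)c1ccccc1/N=C/c1cccs1` has not yet been measured. Its difference from compound 2 is thiophen-2-yl in place of 4-(dimethylamino)phenyl on a carbon with a double bond to nitrogen in the counted terms, with thiophen-2-yl in place of 4-(dimethylamino)phenyl on a carbon with a double bond to nitrogen.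

Among the measured compounds shown here, only one measured step bears on this change. It sits at the same place and is large, beyond the scatter: a number 1.19 log units lower from compound 1 to compound 2 (beyond the scatter) with 4-(dimethylamino)phenyl in place of 3,4-dichlorophenyl. For the measured compounds named here, that step shows that this assay can move substantially with a change at this place, but thiophen-2-yl itself has no measured precedent, and neither group in the new change is 3,4-dichlorophenyl. A step of that size is therefore not carried over. The expected result is a number 0.18 log units lower from compound 2 to compound 3 (within the scatter) as a small downward move that would stay within the scatter. The estimated value for compound 3 is 4.85 with an expected range from 4.4 to 5.3 on this scale.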

Compound 3, partition coefficient: 4.78
For compound 3 the middle estimate is 0.07 log units above the measured one; the range from low to high includes it.
By their numbers in this assay, from the lowest: compounds 3 and 2 (each within the scatter of the next); then compound 1.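

In this assay, the step of a number 0.25 log units lower from compound 2 to compound 3 (within the scatter) shows that at this carbon with a double bond to nitrogen, thiophen-2-yl with its 5 heavy atoms and 4-(dimethylamino)phenyl with its 9 heavy atoms cannot be told apart on this read-out. The step of a number 1.44 log units lower from compound 1 to compound 3 (beyond the scatter) is large and beyond the scatter, so a second group now stands well away from 3,4-dichlorophenyl at this place, and the large difference from compound 1 is no longer tied to 4-(dimethylamino)phenyl alone. No supporting data are available to explain this pattern among the three compounds.

The compounds shown leave open where a plain phenyl or a phenyl carrying a single chlorine would fall in this assay and therefore whether the separation of compound 1 requires both chlorine atoms. On these data alone, it is also open how non-aromatic groups at this place, such as an aliphatic amine, a carboxylic acid or a longer alkyl chain, would read against these three compounds.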